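Permeability of a 4-aminoquinoline series with two aryl variations

The source may report more compounds than this note shows. Statements on the series, on what has been measured and on what is new or still open speak of the compounds shown alone.

Compound 1 `CC(C)(C)c1ccc(-c2ccc3c(NCCCNCc4ccco4)ccnc3c2)cc1`: 237 10^-6 cm/s
Compound 2 `Clc1ccc(Oc2ccc3c(NCCCNCc4ccco4)ccnc3c2)cc1`: 317 10^-6 cm/s
Compound 3 `COc1ccc(F)cc1CNCCCNc1ccnc2cc(Oc3ccc(Cl)cc3)ccc12`: 317 10^-6 cm/s

Of the compounds shown here, three have been measured in an ADME assay for permeability, using PAMPA, with a stated time of 30 min, at pH 7.4; on this read-out higher numbers stand for higher permeability and lower numbers for lower permeability. Compound 2 `Clc1ccc(Oc2ccc3c(NCCCNCc4ccco4)ccnc3c2)cc1` gives 317 10^-6 cm/s. Compound 1 `CC(C)(C)c1ccc(-c2ccc3c(NCCCNCc4ccco4)ccnc3c2)cc1`, which carries 4-(tert-butyl)phenyl in place of 4-chlorophenoxy on an aromatic carbon, shows a 1.3-fold lower number from compound 2 to compound 1 (0.13 log units; within the scatter). Compound 3 `COc1ccc(F)cc1CNCCCNc1ccnc2cc(Oc3ccc(Cl)cc3)ccc12` differs from compound 2 in the other arm of the molecule, where (5-fluoro-2-methoxyphenyl in place of furan-2-yl on a saturated chain carbon bound to an amine nitrogen); that change shows no change at the digits printed from compound 2 to compound 3 (within the scatter). Compound 3 thus stands level with compound 2, and the two are the highest of the three numbers, while compound 1 lies a small step lower that is still within the scatter.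

Compound 4 `COc1ccc(F)cc1CNCCCNc1ccnc2cc(-c3ccc(C(C)(C)C)cc3)ccc12` has not yet been measured in this assay. It differs from compound 3 by 4-(tert-butyl)phenyl in place of 4-chlorophenoxy on an aromatic carbon, which is the same change as that made from compound 2 to compound 1, at the same place. On that basis the step in this assay is expected to be a 1.3-fold lower number from compound 3 to compound 4 (0.11 log units; within the scatter), resting on the earlier step of a 1.3-fold lower number from compound 2 to compound 1 (0.13 log units; within the scatter). Compound 4 is therefore estimated at 245 10^-6 cm/s, with a range from 150 10^-6 cm/s to 380 10^-6 cm/s.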

Compound 4, apparent permeability: 237 10^-6 cm/s
Beside the measured number, compound 4's estimate is 1.0-fold (0.01 log units) above it, and the stated range covers the measured number.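

In this assay, 4-(tert-butyl)phenyl in place of 4-chlorophenoxy gives a 1.3-fold lower number from compound 3 to compound 4 (0.13 log units; within the scatter), which agrees with the earlier step for this change: the same change on two cores in this assay, a 1.3-fold lower number (0.13 log units; within the scatter) from compound 2 to compound 1 and a 1.3-fold lower number (0.13 log units; within the scatter) from compound 3 to compound 4, 1.0-fold (0.00 log units) apart, within the scatter of two such steps

The other change, 5-fluoro-2-methoxyphenyl in place of furan-2-yl, gives no change at the digits printed from compound 1 to compound 4 (within the scatter), and it also reads the same on both cores: the same change on two cores in this assay, no change at the digits printed (within the scatter) from compound 2 to compound 3 and no change at the digits printed (within the scatter) from compound 1 to compound 4, 1.0-fold (0.00 log units) apart, within the scatter of two such steps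

Each change therefore carries from one core to the other within these four compounds, but every step lies within the scatter, so this does not show that either change has an effect of its own, and it says nothing about any core beyond these two.

The compounds shown leave open whether another group on the same aromatic carbon, such as an amine or a carboxylic acid, would give a step beyond the scatter in this assay. They also leave open how a longer chain in place of the saturated chain shared by all four compounds would read.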